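The source may hold more compounds than are shown below. What is called first, only, known or untested is meant among the compounds shown, and "the series" means these compounds.

Measured so far in a functional assay on the whole organism for inhibition, with Mythimna separata as the target, with a stated time of 5 days; on this read-out lower numbers stand for an effect already at smaller amounts and higher numbers for an effect only at larger amounts of compound:
compound 1 `CCn1ncc(OCc2nnc(-c3ccccc3)o2)c(Cl)c1=O` — > 299000 nM
compound 2 `CC(C)(C)n1ncc(OCc2nnc(-c3cc(F)c(Cl)cc3Cl)s2)c(Cl)c1=O` — 67100 nM
compound 3 `CC(C)(C)n1ncc(OCc2nnc(-c3cc(F)c(F)cc3F)o2)c(Cl)c1=O` — 75700 nM

In this assay compound 1 gives > 299000 nM, which is a limit of the assay and not a number; (the limit of > 299000 nM in this assay, at which 1 of the 3 values shown sits). Compound 2 gives 67100 nM and compound 3 gives 75700 nM in this assay, and these two values lie within the usual scatter of each other. Compound 1 thus stands only as a limit among the shown numbers, with no measured step leading away from it.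

Compound 4 `CCn1ncc(OCc2nnc(-c3ccc(F)cc3)o2)c(Cl)c1=O` differs from compound 1 by fluoro in place of hydrogen on an aromatic carbon. For the measured compounds named here, no step between measured compounds covers such a change, so the expectation rests on the limit of compound 1 alone. Compound 4 is expected at 250000 nM with a range from 80000 nM to 800000 nM. The step of an at least 1.1-fold lower number from compound 1 to compound 4 (0.07 log units; that floor lies within the scatter) is expected to stay within the scatter, and a limit rather than a number remains likely.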

Compound 4, half-maximal effective concentration: > 299000 nM
Compound 4 ended at the assay's limit; the forecaster's own chance of this, stated with the estimate: 60%; middle value at least 1.1-fold (0.07 log units) away from the limit.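

In this assay, for the compounds shown here, compound 4 gives > 299000 nM, a limit of the assay and not a number, as compound 1 does, so no step between compound 1 and compound 4 can be read. As far as these compounds go, whether phenyl to 4-fluorophenyl changes the effect stays open.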